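From compound 3 to its fluoro analogue

The compounds below may be only part of what the source reports. "The series", "measured", "known", "first", "only" and "open" are said of these compounds alone.

- Compound 1 `CCOC(=O)C1=C(Nc2ccccc2)S/C(=C\c2ccc([N+](=O)[O-])c(O)c2)C1=O`: 12700 nM
- Compound 2 `CCOC(=O)C1=C(Nc2ccccc2)S/C(=C\c2cccc(C(=O)O)c2)C1=O`: 16200 nM
- Compound 3 `CCOC(=O)C1=C(Nc2ccccc2)S/C(=C\c2ccc[nH]2)C1=O`: 71000 nM

All three compounds were tested in a functional assay on K562 cells (Homo sapiens) for inhibition, read by MTT assay, with a stated time of 72 h; a lower number here means a stronger inhibitor, a higher number a weaker inhibitor. Compound 3 gives 71000 nM, the highest number of the three and beyond the scatter from both of the others, so it is the weakest inhibitor of the set.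

Compound 4 `CCOC(=O)C1=C(Nc2cccc(F)c2)S/C(=C\c2ccc[nH]2)C1=O` is made from compound 3 by one small change: fluoro in place of hydrogen on an aromatic carbon. In other words, fluoro takes the place of hydrogen on an aromatic carbon, turning the phenyl into 3-fluorophenyl, while the rest of the structure stays the same.

For the measured compounds named here, only one measured step links two compounds that differ in one place: a 4.4-fold higher number from compound 2 to compound 3 (0.64 log units; beyond the scatter). It is modest, although beyond the scatter, and it concerns a different part of the structure, the group on the double-bonded chain carbon. Going by the values given here, no measured step shows what a change on the anilino ring does in this assay. Without such evidence, no shift beyond the scatter is expected, and the estimated step is a 1.2-fold lower number from compound 3 to compound 4 (0.07 log units; within the scatter).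

For compound 4 the estimate is 60000 nM, with an expected range from 25000 nM to 130000 nM.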

Compound 4, half-maximal inhibitory concentration: > 100000 nM
Compound 4 ended at the assay's limit; the forecaster's own chance of this, stated with the estimate: 15%; at least 1.6-fold (0.22 log units) between middle value and limit.
By their numbers in this assay, from the lowest: compounds 1 and 2 (each within the scatter of the next); then compound 3. At a limit, above all of these: compound 4.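

Compound 4 is the only compound shown with a change on the anilino ring, so it offers the first reading on this part of the structure. In this assay compound 4 gives > 100000 nM, which is a limit of the assay and not a number. Taken as a floor, the step is an at least 1.4-fold higher number from compound 3 to compound 4 (0.14 log units; that floor lies within the scatter): fluoro in place of hydrogen on this aromatic carbon gave no lower number here, but how far the number rose cannot be told, and the floor itself does not exceed the usual scatter. Compound 4 alone among the compounds shown stands at that limit: the limit of > 100000 nM in this assay, at which 1 of the 4 values shown sits.

The compounds shown leave open whether a different group at this place on the phenyl, such as a methoxy group, an amine or a carboxylic acid, would give a lower number than fluoro does. They also leave open whether the same fluoro change would read differently with 3-carboxyphenyl in place of 1H-pyrrol-2-yl, where the starting number in this assay lies within the measurable range, as compound 2 gives 16200 nM.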